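The compounds below may be only part of what the source reports. "The series", "measured", "known", "first", "only" and "open" are said of these compounds alone.

In a functional assay on PC-3 cells (Homo sapiens) for antiproliferative activity, read by MTT assay, with a stated time of 96 h (on this read-out lower numbers stand for stronger inhibition of growth and higher numbers for weaker inhibition of growth), compound 1 (`COc1cccc2ccc(Nc3ccccn3)nc12`) gives 7470 nM and compound 2 (`COc1cccc2ccc(Nc3cc(C)ccn3)nc12`) gives 3820 nM on the same read-out. For the measured compounds named here, compound 3 (`COc1ccc(Cl)c2ccc(Nc3ccccn3)nc12`) stands at 29200 nM as the highest of the three numbers so far. The next compound, compound 4 (`COc1ccc(Cl)c2ccc(Nc3cc(C)ccn3)nc12`), differs from compound 3 by methyl in place of hydrogen on an aromatic carbon and is methyl in place of hydrogen on an aromatic carbon, the change from pyridin-2-yl to 4-methylpyridin-2-yl. Going by the values given here, the one direct precedent is the same change without the chloro group, a 2.0-fold lower number from compound 1 to compound 2 (0.29 log units; within the scatter) in size, so it offers only a weak signal. The chloro step, a 3.9-fold higher number from compound 1 to compound 3 (0.59 log units; beyond the scatter) in size, sets the higher level from which the methyl change now starts. A similar small step toward a lower number is therefore expected in this assay and may not clear the scatter. The estimated step is a 1.9-fold lower number from compound 3 to compound 4 (0.29 log units; within the scatter) on this reasoning. Compound 4 is expected near 15000 nM in this assay with an estimated range from 7000 nM to 32000 nM for repeated measurements.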

Compound 4, concentration for 50% growth inhibition: > 30000 nM
Compound 4: a limit, no number; the forecaster's own chance of this, stated with the estimate: 5%; middle value at least 2.0-fold (0.30 log units) away from the limit.
By their numbers in this assay, from the lowest: compounds 2 and 1 (each within the scatter of the next); then compound 3. At a limit, above all of these: compound 4.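

In this assay compound 4 gives only a limit, > 30000 nM, not a number. The chloro change now has a second case on the methyl-bearing core, with an at least 7.8-fold higher number from compound 2 to compound 4 (0.89 log units; beyond the scatter), so its direction toward a higher number holds for both pairs shown, and the step is at least as far beyond the scatter as the first: the same change on two cores in this assay, a 3.9-fold higher number (0.59 log units; beyond the scatter) from compound 1 to compound 3 and an at least 7.8-fold higher number (0.89 log units; beyond the scatter) from compound 2 to compound 4; the limit leaves it open whether they differ On the chloro-bearing core, methyl opposite the ring nitrogen gives no lower number, only an at least 1.0-fold higher number from compound 3 to compound 4 (0.01 log units; that floor lies within the scatter), a floor rather than a measured size, so any dependence on the core stays unresolved: the same change on two cores in this assay, a 2.0-fold lower number (0.29 log units; within the scatter) from compound 1 to compound 2 and an at least 1.0-fold higher number (0.01 log units; that floor lies within the scatter) from compound 3 to compound 4; the limit leaves it open whether they differ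

From the compounds shown here alone, the true size of both steps into compound 4 remains open. So does whether an amine or a longer chain in place of methyl, opposite the ring nitrogen, would lower the number on either core.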